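Adding a Nitro Group to a Cyclic Chalcone Core

The source may hold more compounds than are shown below. What is called first, only, known or untested is meant among the compounds shown, and "the series" means these compounds.

Compound 1, `COc1cc2c(cc1OC)C(=O)/C(=C/c1cccc([N+](=O)[O-])c1)CC2`: 9000 nM
Compound 2, `COc1cc2c(cc1OC)C(=O)/C(=C/c1cc([N+](=O)[O-])cc([N+](=O)[O-])c1)CC2`: 2000 nM
Compound 3, `COc1cc2c(cc1O)C/C(=C\c1cc(C)c(O)c(C)c1)C2=O`: 530 nM

These three compounds were tested in a functional assay on Jurkat cells (Homo sapiens) for antiproliferative activity, read by MTT assay; a lower number here means a stronger inhibitor, a higher number a weaker inhibitor. Going from compound 1 to compound 2, the change is nitro in place of hydrogen on an aromatic carbon, and it gave a 4.5-fold lower number from compound 1 to compound 2 (0.65 log units; beyond the scatter). Compound 3 differs from compound 1 in more than one place, so the difference between the two cores is not broken down here; compound 3 simply shows the lowest number of the three.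

Compound 4, `COc1cc2c(c([N+](=O)[O-])c1O)C/C(=C\c1cc(C)c(O)c(C)c1)C2=O`, is not yet measured. Its change from compound 3 is nitro in place of hydrogen on an aromatic carbon. This is the same kind of change as from compound 1 to compound 2, but the surroundings differ: in compound 2 the nitro sits meta to a large group and meta to a nitro group, while in compound 4 it sits on a ring that is part of a fused system, ortho to a fused ring, ortho to a hydroxy group, meta to a fused ring and meta to a methoxy group. Going by the values given here, because the only precedent is a 4.5-fold lower number from compound 1 to compound 2 (0.65 log units; beyond the scatter) at a different place, the expected step for compound 4 is a 1.2-fold lower number from compound 3 to compound 4 (0.07 log units; within the scatter), a small one with wide uncertainty. Compound 4 is therefore estimated at 450 nM, expected to fall between 130 nM and 1500 nM.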

Compound 4, half-maximal inhibitory concentration: 9300 nM
For compound 4 the middle estimate is 21-fold (1.32 log units) below the measured one; the measured number lies above the stated range.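

Set ortho to a hydroxy group and meta to a methoxy group, the nitro group gave an 18-fold higher number from compound 3 to compound 4 (1.24 log units; beyond the scatter) in this assay. The same change therefore did not carry over from one core to the other, and its direction reversed: the same change on two cores in this assay, a 4.5-fold lower number (0.65 log units; beyond the scatter) from compound 1 to compound 2 and an 18-fold higher number (1.24 log units; beyond the scatter) from compound 3 to compound 4, 79-fold (1.90 log units) apart, beyond the scatter of two such steps

This does not show the reason: the nitro groups sit in different surroundings on cores that differ in more than one place, and one pair per core cannot separate the effect of position from that of the core. Left open is how an amine or a chlorine atom in place of that same hydrogen of compound 3 would fare. Also open, on these data alone, is whether nitro at another aromatic carbon of compound 3 would give a step of the same direction.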